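The source may hold more compounds than are shown below. What is called first, only, known or untested is meant among the compounds shown, and "the series" means these compounds.

Values so far in a functional assay on Ehrlich cells (Mus musculus) for inhibition; a lower number here means a stronger inhibitor, a higher number a weaker inhibitor
compound 1 `O=C(O)c1cnc2cc(OCc3cccc4ccccc34)ccc2c1O` gives 85100 nM
compound 2 `O=C(O)c1cnc2cc(O)ccc2c1O` gives 912000 nM
compound 3 `COc1ccc2c(O)c(C(=O)O)cnc2c1` gives 525000 nM

Compound 3 at 525000 nM stands level with compound 2 within the scatter. Compound 1 gives 85100 nM, and compound 3 has the higher number of the two, by a gap beyond the scatter. Going by the values given here, the only measured step, a 1.7-fold lower number from compound 2 to compound 3 (0.24 log units; within the scatter), puts a methyl in place of a hydrogen on an oxygen on an aromatic ring.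

Compound 4 `NS(=O)(=O)c1ccc2c(O)c(C(=O)O)cnc2c1` has not been measured yet. It differs from compound 3 in one place, with sulfamoyl in place of methoxy on an aromatic carbon. Among the compounds with values here, no measured pair makes this exact exchange, so the evidence is indirect. The one measured step that bears on it, shown above, stayed within the scatter. Compound 1 at 85100 nM shows that a different group on the shared core can go with a clearly lower number, but sulfamoyl, like methoxy, has no ring. No step beyond the scatter is therefore expected in this assay. As far as these compounds go, the expected step is a 1.1-fold higher number from compound 3 to compound 4 (0.06 log units; within the scatter), and its direction remains open. Compound 4 is estimated at 600000 nM, with an expected range from 220000 nM to 1500000 nM.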

Compound 4, half-maximal inhibitory concentration: 3390000 nM
Compound 4: the middle estimate sits 5.7-fold (0.75 log units) below what was measured; measured number above the stated range.
By their numbers in this assay, from the lowest: compound 1; then compounds 3 and 2 (each within the scatter of the next); then compound 4.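

In this assay, this position on the shared core proves able to move the number: hydroxy and methoxy stand level within the scatter, yet putting sulfamoyl in place of methoxy gives a 6.5-fold higher number from compound 3 to compound 4 (0.81 log units; beyond the scatter) and putting it in place of hydroxy gives a 3.7-fold higher number from compound 2 to compound 4 (0.57 log units; beyond the scatter) in the same direction, towards a weaker inhibitor. The two steps agree, so the change does not depend on which of the two smaller groups serves as the starting point, and a group with no ring can clearly shift the result here. No measurement available here explains why sulfamoyl goes with the weaker inhibition.

The compounds shown do not tell whether this shift belongs to the sulfamoyl group as a whole or to one part of it, and a methylsulfonyl group or a carboxamide on the same aromatic carbon would help separate those possibilities. Nor do they show how a simple amine, a chlorine atom or a longer alkoxy chain would behave here, so whether anything of similar size can be tolerated remains an open question.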